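Replacing the pyrazole amide of compound 1 with an oxanylmethyl chain

A few compounds are considered here, and "the series" means these few. Any claim that something is new, unique, unknown or untested is made for them only; others in the source may bear on it.

Measured compounds:
compound 1 `O=C(Nc1ccc(C2CCCCC2)cc1)c1cn[nH]c1`: < 1000 nM
compound 2 `O=C(Nc1ccc([C@H]2[C@@H](F)[C@@H](F)C[C@@H](F)[C@H]2F)cc1)c1cn[nH]c1`: <= 1000 nM

The series rests on a shared core carrying an amide. In a physicochemical assay for solubility, measured as kinetic solubility (a higher number here means a more soluble compound, a lower number a less soluble compound), compound 1 gives < 1000 nM, and this is a limit of the assay rather than a number. Compound 2 `O=C(Nc1ccc([C@H]2[C@@H](F)[C@@H](F)C[C@@H](F)[C@H]2F)cc1)c1cn[nH]c1` gives <= 1000 nM in this assay, again a limit. So compound 1 stands at the limit of < 1000 nM in this assay, at which 1 of the 2 values shown sits, and the only other value shown sits at the limit of <= 1000 nM in this assay, at which 1 of the 2 values shown sits; neither compound is placed by a measured number, and no step between measured compounds is available.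

Compound 3 `O=C(CC1CCOCC1)Nc1ccc(C2CCCCC2)cc1` differs from compound 1 by (oxan-4-yl)methyl in place of 1H-pyrazol-4-yl on a carbonyl carbon. Among the measured compounds shown here, with no measured step to lean on, the size and direction of the change in this assay cannot be read from the data; the expectation is a step that stays close to the scatter, with a fair chance that compound 3 also reports only a limit.

Compound 3 is therefore estimated at 1000 nM in this assay, within a range of 300 nM to 5000 nM, which corresponds to an expected step of a number no lower from compound 1 to compound 3 (the limit leaves the size open).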

Compound 3, solubility: < 1000 nM
Compound 3 ended at the assay's limit (the forecaster's own chance of this, stated with the estimate: 55%); the middle value sits exactly at the limit.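

In this assay compound 3 gives < 1000 nM, which is a limit of the assay and not a number. Among the compounds shown here, compound 1 also reports only a limit, and no step from compound 1 to compound 3 can be read. The compounds shown leave open where any of them stands as a number, and whether (oxan-4-yl)methyl in place of 1H-pyrazol-4-yl on a carbonyl carbon shifts the reading at all.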